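A few compounds are considered here, and "the series" means these few. Any claim that something is new, unique, unknown or untested is made for them only; others in the source may bear on it.

Measured so far in an assay on membranes from brain for binding affinity to adenosine receptor A1 (Rattus norvegicus), read by radioligand binding, tested at 20 uM; on this read-out higher numbers stand for more inhibition at the one concentration tested (going by the name of the read-out) and lower numbers for less inhibition:
compound 1 `Cn1c(=O)[nH]c2c(cnn2-c2ccc(N)cc2)c1=N` gives 0%
compound 2 `Cn1c(=O)[nH]c2c(cnn2-c2ccc(Cl)cc2)c1=N` gives 37%
compound 3 `Cn1c(=O)[nH]c2c(cnn2-c2ccccc2F)c1=N` gives 8%

Compound 3 stands second highest of the three numbers. Its value and that of compound 1 lie within the usual scatter of each other, so no order between the two is claimed; compound 2 lies beyond the scatter above both of them. Going by the values given here, the only step between compounds differing in one place is a number 37 percentage points higher from compound 1 to compound 2 (beyond the scatter), which concerns a different group and a different position of the aryl ring and so bears on the present question only loosely.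

Compound 4 `Cn1c(=O)[nH]c2c(cnn2-c2ccccc2)c1=N` differs from compound 3 as follows: hydrogen in place of fluoro on an aromatic carbon. Among the compounds with values here, no measured pair shows what removing this substituent does, and the one large step in the set concerns another change. The expectation is therefore that compound 4 stays close to compound 3, with a step from compound 3 to compound 4 of a number 2 percentage points higher from compound 3 to compound 4 (within the scatter) in this assay , which is expected to lie within the scatter. Compound 4 is estimated at 10%, in a range from 0% to 30%.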

Compound 4, a percentage reported as inhibition, at one concentration (the size of the read-out at that concentration, not a potency): 30%
Compound 4: the middle estimate sits 20 percentage points below what was measured; low and high end bracket the measured number.
By their numbers in this assay, from the lowest: compounds 1 and 3 (each within the scatter of the next); then compounds 4 and 2 (each within the scatter of the next).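

In this assay, hydrogen in place of fluoro on an aromatic carbon ortho to a large group is not a neutral change: a number 22 percentage points higher from compound 3 to compound 4 (beyond the scatter). Compared with the same hydrogen compound, the chloro change gives a number 7 percentage points lower from compound 2 to compound 4 (within the scatter) and the amino change gives a number 30 percentage points higher from compound 1 to compound 4 (beyond the scatter), so among these substituents only chloro stays within the scatter of hydrogen, while fluoro and amino both lie beyond it on the low side. No evidence at hand explains these differences.

From the compounds shown here alone, it remains open whether a methyl or methoxy group on that same carbon would track with fluoro or with hydrogen, and whether fluoro elsewhere on the ring would behave as it does here. Going by these compounds alone, these single-concentration percentages also give no potency for any compound.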